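The source may report more compounds than this note shows. Statements on the series, on what has been measured and on what is new or still open speak of the compounds shown alone.

Working notes on a small set of methyl(propargyl)amino ethers. Compound 1 `C#CCN(C)CCCCOc1ccc2c(c1)CCCC2=O` gives in an assay on BTI cells for inhibition of Amine oxidase [flavin-containing] B (Homo sapiens), read by fluorescence and Amplex Red, with a stated time of 15 min (a higher number here means a weaker inhibitor, a lower number a stronger inhibitor), a value of 72.5 nM. Compound 2 `C#CCN(C)CCCCCOc1ccc2c(c1)CCCC2=O` differs from it by (methyl(propargyl)amino)methyl in place of methyl(propargyl)amino on a saturated chain carbon, four bonds along the chain from an oxygen on an aromatic ring and gives in this assay 46.3 nM; the step is a 1.6-fold lower number from compound 1 to compound 2 (0.19 log units; within the scatter). Compound 3 `C#CCN(C)CCCCOc1ccc(C(C)=O)cc1OC` is built on another core; the difference between the two cores is not broken down here. In this assay compound 3 gives 1150 nM, the highest number of the three measured compounds, beyond the scatter from both compound 1 and compound 2. Compound 4 `C#CCN(C)CCCCCOc1ccc(C(C)=O)cc1OC` stands to compound 3 as compound 2 stands to compound 1: the change is (methyl(propargyl)amino)methyl in place of methyl(propargyl)amino on a saturated chain carbon, four bonds along the chain from an oxygen on an aromatic ring, the same change at the same place. Going by the values given here, only one measured pair shows what this change does, and there the step was a 1.6-fold lower number from compound 1 to compound 2 (0.19 log units; within the scatter), within the scatter, so for compound 4 a step of similar small size is expected, a 1.5-fold lower number from compound 3 to compound 4 (0.19 log units; within the scatter). Whether the change carries over to the core of compound 3 is not tested by any other pair here, so the range is kept wide. For compound 4 in this assay the estimated value is 750 nM, between 300 nM and 1900 nM.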

Compound 4, half-maximal inhibitory concentration: 6520 nM
Compound 4: the middle estimate sits 8.7-fold (0.94 log units) below what was measured; measured number outside the range, above it.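

In this assay the change to (methyl(propargyl)amino)methyl in place of methyl(propargyl)amino reads a 5.7-fold higher number from compound 3 to compound 4 (0.75 log units; beyond the scatter), and set beside the earlier pair it does not behave alike on the two cores: the same change on two cores in this assay, a 1.6-fold lower number (0.19 log units; within the scatter) from compound 1 to compound 2 and a 5.7-fold higher number (0.75 log units; beyond the scatter) from compound 3 to compound 4, 8.9-fold (0.95 log units) apart, beyond the scatter of two such steps. A step read on one core in this series therefore cannot be carried to the other core as it stands, and the small step on the core of compound 1 gives no safe guide to the core of compound 3. The two pairs do not show why the cores part, nor how the change would run on a third core, and they give no rule for the series as a whole.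

Open, as far as these compounds go, is whether a longer chain, 2-(methyl(propargyl)amino)ethyl in place of (methyl(propargyl)amino)methyl, would widen or narrow the gap between the two cores. Also open, from the compounds shown here alone, is whether the two cores would still part with another amine, such as dimethylamino, in place of the methyl(propargyl)amino end of the chain.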